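Swapping a Thioether for a Cyclopropylamine: Cytotoxicity Outlook

A few compounds are considered here, and "the series" means these few. Any claim that something is new, unique, unknown or untested is made for them only; others in the source may bear on it.

Compound 1 `CC(C)CSc1nc(N)nc2c1ncn2/C=C1/CC1(CO)CO` has been examined in an ADME assay on Akata cells (Homo sapiens) for cytotoxicity, with a stated time of 7 days; a higher number here means that more compound is tolerated, a lower number that less compound is tolerated. In this assay compound 1 gives > 20000 nM, which is a limit of the assay and not a number. Among the measured compounds shown here, compound 2 `CCCSc1nc(N)nc2c1ncn2/C=C1/CC1(CO)CO` is its only measured neighbour. In this assay compound 2 likewise gives > 20000 nM, again a limit. The step that the two limits leave unreadable from compound 1 to compound 2 therefore cannot be read. Compound 1 thus stands at the limit, as does every value shown: the limit of > 20000 nM in this assay, at which 2 of the 2 values shown sit.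

Compound 3 `Nc1nc(NC2CC2)c2ncn(/C=C3/CC3(CO)CO)c2n1` remains to be measured. It differs from compound 1 in cyclopropylamino in place of isobutylsulfanyl on an aromatic carbon. For the measured compounds named here, no measured step bears on this change, and the single step between measured compounds is not readable, so only the two limits guide the outlook. The change is expected to amount to a step that the limit leaves unreadable from compound 1 to compound 3. For compound 3 in this assay the estimated value is 30000 nM, with a range from 12000 nM to 100000 nM, most likely reported again as a limit.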

Compound 3, half-maximal cytotoxic concentration: > 20000 nM
Compound 3: a limit, no number (the forecaster's own chance of this, stated with the estimate: 80%); the middle value is on the limit's open side.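

In this assay compound 3 gives > 20000 nM, which is a limit of the assay and not a number. The steps to compound 3 from compound 1 and compound 2 therefore cannot be read: the limit of > 20000 nM in this assay, at which 3 of the 3 values shown sit. The compounds shown leave open at what concentration any of the three becomes cytotoxic, and whether cyclopropylamino and the two sulfanyl groups differ at all.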